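The source may hold more compounds than are shown below. What is called first, only, known or untested is meant among the compounds shown, and "the series" means these compounds.

Compound 1 (`Cc1ccc(C(=O)N[C@@H]2[C@@H](O)[C@H](n3cnc4c(NC5CCCC5)ncnc43)O[C@@H]2C)cc1C`) in an assay on isolated protein for binding affinity to adenosine receptor A1 (Rattus norvegicus), in the absence of a further agent (a higher number here means a weaker inhibitor, a lower number a stronger inhibitor), gives 236 nM.
Compound 2 (`CC(C)c1ccc(C(=O)N[C@@H]2[C@@H](O)[C@H](n3cnc4c(NC5CCCC5)ncnc43)O[C@@H]2C)cc1`) gives 270 nM.
Compound 3 (`C[C@H]1O[C@@H](n2cnc3c(NC4CCCC4)ncnc32)[C@H](O)[C@H]1NC(=O)CCCc1cccs1`) gives 55 nM.

Compound 3 carries the lowest of the three numbers: against compound 1 the step is a 4.3-fold lower number from compound 1 to compound 3 (0.63 log units; beyond the scatter), and against compound 2 it is a 4.9-fold lower number from compound 2 to compound 3 (0.69 log units; beyond the scatter). Between compound 1 and compound 2 the step is a 1.1-fold higher number from compound 1 to compound 2 (0.06 log units; within the scatter), so the two aryl amides cannot be told apart.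

Compound 4 (`C[C@H]1O[C@@H](n2cnc3c(NC4CCCC4)ncnc32)[C@H](O)[C@H]1NC(=O)CCCOc1ccccc1`) differs from compound 3 in one place: phenoxy in place of thiophen-2-yl on a saturated chain carbon, three bonds along the chain from a carbonyl carbon. Among the measured compounds shown here, none of the measured steps covers this change. The steps that reach compound 3 concern the exchange of an aryl group directly on the carbonyl for a saturated chain ending in thiophen-2-yl, and the step from compound 1 to compound 2 only shows that two different aryl groups on the carbonyl give the same result. Since the chain and the amide are kept in compound 4 and only the terminal aromatic group is exchanged, a step that stays within the scatter, or a modest one in either direction, is expected. The estimate for compound 4 is 75 nM, with a range from 25 nM to 220 nM, which means an expected step of a 1.4-fold higher number from compound 3 to compound 4 (0.13 log units; within the scatter).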

Compound 4, inhibition constant: 473 nM
Compound 4: the middle estimate sits 6.3-fold (0.80 log units) below what was measured, and the stated range ends below it.
By their numbers in this assay, from the lowest: compound 3; then compounds 1, 2 and 4 (each within the scatter of the next).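

In this assay the end of the chain proves to matter: with the amide and the saturated chain kept, phenoxy in place of thiophen-2-yl gives an 8.6-fold higher number from compound 3 to compound 4 (0.93 log units; beyond the scatter) and so removes the advantage that compound 3 held over the aryl amides. That advantage therefore cannot be credited to the saturated chain alone, as 3-phenoxypropyl in place of 4-isopropylphenyl gives a 1.8-fold higher number from compound 2 to compound 4 (0.24 log units; within the scatter) and 3-phenoxypropyl in place of 3,4-dimethylphenyl gives a 2.0-fold higher number from compound 1 to compound 4 (0.30 log units; within the scatter) and compound 4 cannot be told apart from either aryl amide. Nothing available here explains the difference between phenoxy and thiophen-2-yl.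

The change brings in an oxygen and exchanges the ring in a single step, so the compounds shown do not say which of the two accounts for the result; a 3-phenylpropyl group on the carbonyl carbon would keep the six-membered ring without the oxygen. As far as these compounds go, how the length of the chain bears on the number also stays open, and a 2-(thiophen-2-yl)ethyl or 4-(thiophen-2-yl)butyl group would address that.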